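Replacing the sulfur-bearing group in compound 3

The compounds below may be only part of what the source reports. "The series", "measured", "known", "first", "only" and "open" are said of these compounds alone.

Compound 3 `C[S+]([O-])C(Cc1cccc(OCC(=O)O)c1)c1nc(-c2ccccc2)c(-c2ccccc2)o1` in a functional assay for inhibition, with Homo sapiens as the target (a higher number here means a weaker inhibitor, a lower number a stronger inhibitor), gives 7080 nM, the second highest of the three numbers measured. Compound 2 `O=C(O)COc1cccc(/C=C(\C(=O)O)c2nc(-c3ccccc3)c(-c3ccccc3)o2)c1` gives 20300 nM, and compound 1 `CCOC(=O)/C(=C\c1cccc(OCC(=O)O)c1)c1nc(-c2ccccc2)c(-c2ccccc2)o1` gives 360 nM. Among the compounds with values here, the only single-site step measured, a 56-fold higher number from compound 1 to compound 2 (1.75 log units; beyond the scatter), concerns a different part of the molecule and says nothing about the chain carbon altered here. Compound 4 `O=C(O)COc1cccc(CC(CCCO)c2nc(-c3ccccc3)c(-c3ccccc3)o2)c1` differs from compound 3 as follows: a group of 4 heavy atoms (3 carbon, 1 oxygen; no ring) in place of a group of 3 heavy atoms (1 carbon, 1 oxygen, 1 sulfur; no ring), on a saturated chain carbon bound to an aromatic carbon and a saturated chain carbon. Within the data shown here, no measured step bears on this change, so in this assay no step beyond the scatter is expected, with a wide range to cover the lack of comparable data. Compound 4 is therefore expected to give 5000 nM, between 1500 nM and 20000 nM. This estimate means a 1.4-fold lower number from compound 3 to compound 4 (0.15 log units; within the scatter).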

Compound 4, half-maximal inhibitory concentration: 1700 nM
Compound 4: middle estimate off by 2.9-fold (0.47 log units), on the high side, within the range that was stated.
By their numbers in this assay, from the lowest: compound 1; then compound 4; then compound 3; then compound 2.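

In this assay the group on the saturated chain carbon bound to an aromatic carbon and a saturated chain carbon does affect the read-out: 3-hydroxypropyl in place of the sulfur-bearing group gives a 4.2-fold lower number from compound 3 to compound 4 (0.62 log units; beyond the scatter) and is a modest step beyond the scatter. Within the data shown here, this is the first reading at this position. Nothing measured here explains the step.

The compounds shown do not separate the effect of the chain from that of its terminal hydroxyl, which a plain propyl or a 3-aminopropyl group would address. From the compounds shown here alone, the preferred chain length also stays open, as does the effect of a carboxylic acid at the chain end.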